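The source may hold more compounds than are shown below. What is called first, only, known or untested is meant among the compounds shown, and "the series" means these compounds.

Three compounds have been measured in a functional assay on HT-1080 cells (Homo sapiens) for antiproliferative activity, read by sulforhodamine B assay, with a stated time of 48 h; a lower number here means a stronger inhibitor, a higher number a weaker inhibitor:

Compound 1, `CC(=O)Nc1cccc(S(=O)(=O)Oc2ccccc2C(C)C)c1`, gives 21000 nM.
Compound 2, `CCCC(=O)Nc1cccc(S(=O)(=O)Oc2ccccc2C(C)C)c1`, gives 15000 nM.
Compound 3, `CCCC(=O)Nc1ccc(S(=O)(=O)Oc2ccccc2C(C)C)cc1`, gives 950 nM.

Among the measured compounds shown here, the only single-point change among the measured compounds is ethyl in place of hydrogen on a saturated chain carbon bound to a carbonyl carbon, and it made a 1.4-fold lower number from compound 1 to compound 2 (0.15 log units; within the scatter). Compound 3 carries a different core; the difference between the two cores is not broken down here. What the values show is that compound 3 gives the lowest number of the three, and its gaps to compound 1 and to compound 2 both lie beyond the scatter, so compound 3 is the strongest inhibitor measured so far.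

Compound 4, `CCCCCC(=O)Nc1ccc(S(=O)(=O)Oc2ccccc2C(C)C)cc1`, has not yet been measured. It differs from compound 3 by ethyl in place of hydrogen on a saturated chain carbon, three bonds along the chain from a carbonyl carbon. This is the same kind of change as that from compound 1 to compound 2, but the place is not the same: there the ethyl entered on a saturated chain carbon bound to a carbonyl carbon, whereas here it enters on a saturated chain carbon three bonds along the chain from a carbonyl carbon. Because the earlier step of this kind was a 1.4-fold lower number from compound 1 to compound 2 (0.15 log units; within the scatter), the step from compound 3 to compound 4 is expected to be small, about a 1.3-fold lower number from compound 3 to compound 4 (0.10 log units; within the scatter). Compound 4 is therefore estimated at 750 nM, most likely between 300 nM and 2500 nM.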

Compound 4, half-maximal inhibitory concentration: 6300 nM
For compound 4 the middle estimate is 8.4-fold (0.92 log units) below the measured one; the measured number lies above the stated range.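

In this assay, ethyl in place of hydrogen, here on a saturated chain carbon three bonds along the chain from a carbonyl carbon, gives a 6.6-fold higher number from compound 3 to compound 4 (0.82 log units; beyond the scatter) and weakens the inhibitor, so the earlier step does not repeat on the core of compound 3: the same change on two cores in this assay, a 1.4-fold lower number (0.15 log units; within the scatter) from compound 1 to compound 2 and a 6.6-fold higher number (0.82 log units; beyond the scatter) from compound 3 to compound 4, 9.3-fold (0.97 log units) apart, beyond the scatter of two such steps.
The change therefore did not carry over from one core to the other in this series, and the result of one step could not be read across to the other. What this does not show is why the two steps differ: the ethyl enters at a different place on the chain in each, so the effect of the core cannot be separated from that of the place, and two steps cannot establish a general rule.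

The compounds shown leave open how a pentyl chain would read on the core of compound 1, which would set both cores side by side with the same chain. They also leave open how a propyl chain extended by a single methyl, a branched chain, a longer chain or a terminal amine would read on the core of compound 3.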